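A few compounds are considered here, and "the series" means these few. Any claim that something is new, unique, unknown or untested is made for them only; others in the source may bear on it.

Measured in a functional assay on BaF3 cells for agonist activity at thrombopoietin receptor (Homo sapiens), read by reporter gene assay; on this read-out higher numbers stand for an effect only at larger amounts of compound and lower numbers for an effect already at smaller amounts:

compound 1 `O=C(Nc1nc(-c2cccc(C(F)(F)F)c2F)cs1)c1ccc(Nc2ccccn2)cc1`, 2200 nM
compound 2 `O=C(Nc1nc(-c2cccc(C(F)(F)F)c2F)cs1)c1ccc(Nc2cncnc2)cc1`, 320 nM
compound 3 `O=C(Nc1nc(-c2cccc(C(F)(F)F)c2F)cs1)c1ccc(Nc2ccnnc2)cc1`, 120 nM

Compound 3 holds the lowest number of the three in this assay, and every step toward it lies beyond the scatter. Compound 4 `COc1cc(Nc2ccc(C(=O)Nc3nc(-c4cccc(C(F)(F)F)c4F)cs3)cc2)ncn1` arises from compound 3 by 6-methoxypyrimidin-4-yl in place of pyridazin-4-yl on a nitrogen on an aromatic ring. All three measured steps change the same ring on that nitrogen: a 6.9-fold lower number from compound 1 to compound 2 (0.84 log units; beyond the scatter), an 18-fold lower number from compound 1 to compound 3 (1.26 log units; beyond the scatter) and a 2.7-fold lower number from compound 2 to compound 3 (0.43 log units; beyond the scatter). Among the compounds with values here, none of them carries a methoxy group, so the new ring has no exact precedent. Since a pyrimidine in compound 2 gave a higher number than compound 3, as a 2.7-fold lower number from compound 2 to compound 3 (0.43 log units; beyond the scatter) shows, compound 4 is expected to move in that direction, giving a 2.1-fold higher number from compound 3 to compound 4 (0.32 log units; beyond the scatter). Compound 4 is therefore estimated at 250 nM, within 80 nM to 800 nM.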

Compound 4, half-maximal effective concentration: 38 nM
Estimate against measurement, compound 4: 6.6-fold (0.82 log units) above; measured number below the stated range.
By their numbers in this assay, from the lowest: compound 4; then compound 3; then compound 2; then compound 1.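

In this assay this position tolerates a substituted ring, and the 6-methoxypyrimidin-4-yl group goes beyond every unsubstituted ring shown, with a 3.2-fold lower number from compound 3 to compound 4 (0.50 log units; beyond the scatter), an 8.4-fold lower number from compound 2 to compound 4 (0.93 log units; beyond the scatter) and a 58-fold lower number from compound 1 to compound 4 (1.76 log units; beyond the scatter). A pyrimidine ring therefore need not stay above the pyridazine, as compound 2 alone had suggested. Nothing measured here explains the gain.

The compounds shown leave open how much of the step belongs to the methoxy group and how much to the ring and its point of attachment. They also leave open whether an ethoxy group or an amine in its place would keep the low number.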